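Neopentyl to isopentyl on the shared core

A few compounds are considered here, and "the series" means these few. Any claim that something is new, unique, unknown or untested is made for them only; others in the source may bear on it.

Among the measured compounds shown here, in an ADME assay on liver for metabolic stability, with Liver microsome (Homo sapiens) as the target, read by LC-MS, using microsomes (a higher number here means faster removal of the compound, a lower number slower removal), compound 3 `CC(C)(C)C[C@@H](O)C(=O)N1N=CC[C@H]1C(=O)NCc1cc(Cl)ccc1-n1cnnn1` gives 22 mL.min-1.g-1 and is the only measured compound with an actual number. Compound 1 `Cc1cccc([C@@H](O)C(=O)N2N=CC[C@H]2C(=O)NCc2cc(Cl)ccc2-n2cnnn2)c1` gives < 12 mL.min-1.g-1 as a limit of the assay and not a number. Compound 2 `CC1(C[C@@H](O)C(=O)N2N=CC[C@H]2C(=O)NCc2cc(Cl)ccc2-n2cnnn2)CC1` gives < 12 mL.min-1.g-1 as a limit of the assay as well.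

Compound 4 `CC(C)CC[C@@H](O)C(=O)N1N=CC[C@H]1C(=O)NCc1cc(Cl)ccc1-n1cnnn1` keeps the shared core and differs from compound 3 by isobutyl in place of tert-butyl on a saturated chain carbon, two bonds along the chain from a carbonyl carbon and an oxygen on a saturated carbon with isobutyl in place of tert-butyl on a saturated chain carbon, two bonds along the chain from a carbonyl carbon and an oxygen on a saturated carbon. The two have the same atoms, joined differently.

The closest measured change is an at least 1.8-fold higher number from compound 2 to compound 3 (0.26 log units; that floor lies within the scatter) at this same place. The other is an at least 1.8-fold higher number from compound 1 to compound 3 (0.26 log units; that floor lies within the scatter) where neopentyl replaces 3-methylphenyl. Both give only a floor and not an exact size, and neither tests an isobutyl group directly. Compound 3 with its 22 mL.min-1.g-1 is therefore the anchor for the expectation, and no step beyond the scatter is expected. The estimate is a 1.2-fold higher number from compound 3 to compound 4 (0.07 log units; within the scatter) in this assay as a small upward drift at most. For compound 4 the expected value is 26 mL.min-1.g-1 with an estimated range from 13 mL.min-1.g-1 to 52 mL.min-1.g-1 in this reading.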

Compound 4, intrinsic clearance in microsomes: 47 mL.min-1.g-1
The estimate for compound 4 lay 1.8-fold (0.26 log units) below the measured number; the measured number falls inside the stated range.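

In this assay, among the compounds shown here, isobutyl in place of tert-butyl gives a 2.1-fold higher number from compound 3 to compound 4 (0.33 log units; beyond the scatter), the only step at this place with a number at both ends. It shows that two groups with the same atoms, joined differently, can be separated here by a step beyond the scatter, which the earlier floors, all within the scatter, could not show. Isobutyl in place of 1-methylcyclopropyl gives an at least 3.9-fold higher number from compound 2 to compound 4 (0.59 log units; beyond the scatter), and isopentyl in place of 3-methylphenyl gives an at least 3.9-fold higher number from compound 1 to compound 4 (0.59 log units; beyond the scatter), so both floors now clear the scatter.

As far as these compounds go, the step between compound 1 and compound 2 cannot be read, and the true size of the steps from either compound stays unknown, because both carry a limit of the assay and not a number: the limit of < 12 mL.min-1.g-1 in this assay, at which 2 of the 4 values shown sit. Whether a longer chain or an amine at this place would give a number nearer that of compound 3 or that of compound 4 stays open.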